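From 2-fluorophenyl to 4-methoxyphenyl on a sulfonyl sulfur

The compounds below may be only part of what the source reports. "The series", "measured", "known", "first", "only" and "open" are said of these compounds alone.

Compound 1 `O=S(=O)(Nc1ccc(-c2nc3ccccc3o2)cc1)c1cccc(Cl)c1`: > 100000 nM (a limit)
Compound 2 `O=S(=O)(Nc1ccc2oc(-c3ccccc3)nc2c1)c1ccc(F)c(C(F)(F)F)c1`: > 100000 nM (a limit)
Compound 3 `O=S(=O)(Nc1ccc2oc(-c3ccccc3)nc2c1)c1ccccc1F`: 72000 nM

These compounds were tested in an ADME assay on HEK293 cells (Homo sapiens) for cytotoxicity, read by resazurin assay, with a stated time of 48 h; a higher number here means that more compound is tolerated, a lower number that less compound is tolerated. In this assay, going by the values given here, compound 3 gives 72000 nM, the only true number in the set. Compound 1 reads > 100000 nM, which is a limit of the assay and not a number. Compound 2 reads > 100000 nM, which is also a limit. Taken together, the results show (the limit of > 100000 nM in this assay, at which 2 of the 3 values shown sit).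

Among the compounds with values here, compound 4 `COc1ccc(S(=O)(=O)Nc2ccc3oc(-c4ccccc4)nc3c2)cc1` has 4-methoxyphenyl in place of 2-fluorophenyl on a sulfonyl sulfur, the one difference from compound 3: 4-methoxyphenyl in place of 2-fluorophenyl on a sulfonyl sulfur.

Within the data shown here, no pair of measured compounds shows a change of this kind, so the data give no size for it. The expectation is therefore no shift beyond the usual scatter in this assay, in either direction, starting from compound 3 at 72000 nM. The expected result is a 1.1-fold higher number from compound 3 to compound 4 (0.05 log units; within the scatter). The estimate for compound 4 is 80000 nM, with an expected range from 35000 nM to 150000 nM.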

Compound 4, half-maximal cytotoxic concentration: 91000 nM
For compound 4 the middle estimate is 1.1-fold (0.06 log units) below the measured one; measured number inside the range.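

In this assay, the sulfonyl sulfur now offers a comparison with true numbers on both sides: a 1.3-fold higher number from compound 3 to compound 4 (0.10 log units; within the scatter). So 4-methoxyphenyl can stand in place of 2-fluorophenyl at this position with no shift beyond the usual scatter, even though the incoming group carries a hydrogen-bond acceptor and the outgoing one does not. The other compounds shown could not offer such a reading, and much of the set still rests on a limit of the assay rather than a number: the limit of > 100000 nM in this assay, at which 2 of the 4 values shown sit.

Going by these compounds, it remains open whether a phenyl ring bearing an amine or a carboxylic acid would give a shift beyond the scatter at this position. On these data alone, it is equally open how a short alkyl chain would read there in place of the phenyl ring.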